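Cytotoxicity notes for compounds 1 to 3

This account rests on a few compounds, and the source may have more. Where it says the series, first, only, none or still open, it means among the compounds named here.

Measured so far:
compound 1 `COc1cc2ncnc(-n3nc(N)nc3N)c2cc1OC` — > 33000 nM
compound 2 `COc1cc2ncnc(-n3nc(-c4ccccn4)nc3N)c2cc1OCc1ccccc1` — > 27000 nM

In an ADME assay on BJ cells (Homo sapiens) for cytotoxicity, with a stated time of 72 h (a higher number here means that more compound is needed for the effect, a lower number that less compound is needed), compound 1 gives > 33000 nM, which is a limit of the assay and not a number. In this assay compound 2 gives > 27000 nM, likewise only a limit. Within the data shown here, compound 2 therefore stands at a limit, and the one other value shown is a limit as well: the limit of > 27000 nM in this assay, at which 1 of the 2 values shown sits, and the limit of > 33000 nM in this assay, at which 1 of the 2 values shown sits, are the two entries. Among the measured compounds shown here, no step between measured compounds exists, so nothing sets a size for a change.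

Compound 3 `CCOC(=O)NCCCOc1cc2c(-n3nc(-c4ccccn4)nc3N)ncnc2cc1OC` differs from compound 2 in one place: 2-((ethoxycarbonyl)amino)ethyl in place of phenyl on a saturated chain carbon bound to an oxygen on an aromatic ring. For compound 3 the expected step in this assay is a step that the limit leaves unreadable from compound 2 to compound 3, none beyond the scatter. Compound 3 is expected in this assay at 30000 nM, with a range from 10000 nM to 100000 nM, and most probably once more reported only as a limit.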

Compound 3, half-maximal effective concentration: > 11000 nM
Compound 3 ended at the assay's limit (the forecaster's own chance of this, stated with the estimate: 75%); the middle value is on the limit's open side.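

In this assay, among these compounds, compound 2 and compound 3 both stand at limits, so no step between them can be read. The compounds shown leave open at which concentration any of them reaches the half-maximal effect, and whether 2-((ethoxycarbonyl)amino)ethyl in place of phenyl changes the read-out at all.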